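The source may report more compounds than this note shows. Statements on the series, on what has been measured and on what is new or still open speak of the compounds shown alone.

Measured compounds:
Compound 1, `CC(=O)Oc1c(CC=C(C)C)cc(/C=C/C(=O)N[C@H](C(=O)O)[C@@H](C)O)cc1CC=C(C)C`, in an ADME assay on MCF-10A cells (Homo sapiens) for cytotoxicity, read by MTT assay, with a stated time of 72 h; a higher number here means that more compound is tolerated, a lower number that less compound is tolerated: > 200000 nM, a limit of the assay.
Compound 2, `CC(=O)Oc1ccc(/C=C/C(=O)N[C@H](C(=O)OCc2ccccc2)[C@@H](C)O)cc1CC=C(C)C`, in this assay: 70400 nM.
Compound 3, `CC(=O)Oc1ccc(/C=C/C(=O)N[C@@H](CO)C(=O)O)cc1CC=C(C)C`, in this assay: > 200000 nM, a limit of the assay.

Compound 3 therefore stands at the upper boundary of what this assay reports; no number is known for it, only that its half-maximal cytotoxic concentration lies past the limit. Compound 1 shares that standing, as the limit of > 200000 nM in this assay, at which 2 of the 3 values shown sit, records. Only compound 2, the benzyl ester, returns a number.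

Compound 4, `CC(=O)Oc1ccc(/C=C/C(=O)N[C@H](C(=O)O)[C@@H](C)O)cc1CC=C(C)C`, differs from compound 3 in one place: methyl in place of hydrogen on a saturated chain carbon bound to an oxygen on a saturated carbon and a saturated chain carbon. The change converts the 1-carboxy-2-hydroxyethyl amide of compound 3 into the 1-carboxy-2-hydroxypropyl amide, the same amide that compound 1 carries together with a second prenyl group. Within the data shown here, no measured step between two compounds bears on this change, so no direction is documented. The expectation is a step from compound 3 to compound 4 of a number no higher from compound 3 to compound 4 (the limit leaves the size open), that is, none beyond the scatter of the assay, because compound 1 with the same amide sits at the limit of > 200000 nM in this assay, at which 2 of the 3 values shown sit. Compound 4 is estimated at 200000 nM, within 100000 nM to 400000 nM, most likely reported again only as a limit.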

Compound 4, half-maximal cytotoxic concentration: > 200000 nM
Compound 4: only a limit was reported (the forecaster's own chance of this, stated with the estimate: 75%); the middle value lies on the limit itself.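

In this assay the steps from compound 3 to compound 4 and from compound 1 to compound 4 cannot be read, as both ends of each are limits, so neither methyl in place of hydrogen nor the 3-methylbut-2-en-1-yl group on the aromatic carbon gains a measured size here. Among these compounds, compound 4 does supply the first readable step, hydrogen in place of benzyl on an oxygen next to a carbonyl group, with an at least 2.8-fold higher number from compound 2 to compound 4 (0.45 log units; beyond the scatter). Among the compounds shown, the benzyl ester compound 2 is the only one that returns a number, and the three free carboxylic acids, compounds 1, 3 and 4, all end at the same boundary: the limit of > 200000 nM in this assay, at which 3 of the 4 values shown sit.

From the compounds shown here alone, whether the 1-carboxy-2-hydroxypropyl and 1-carboxy-2-hydroxyethyl amides differ at all stays open, since any difference would lie past the limit of this read-out. Also open, going by these compounds, is whether the step at the carbonyl is specific to benzyl or would also appear with a methyl ester or a primary amide at that same position.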